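The source may report more compounds than this note shows. Statements on the series, on what has been measured and on what is new or still open speak of the compounds shown alone.

Measured so far in an assay on isolated protein for inhibition of Amine oxidase [flavin-containing] A (Homo sapiens), read by spectrophotometry; a lower number here means a stronger inhibitor, a higher number a weaker inhibitor:
compound 1, `CCCOc1ccc(C2CNC(=O)CS2)cc1`: 40000 nM
compound 2, `CCOc1ccc(C2CNCCS2)cc1`: 9600 nM
compound 3, `CCCOc1ccc(C2CNCCS2)cc1`: 6620 nM

Compound 2 stands second highest of the three numbers. Its nearest neighbour is compound 3, and the difference between them is within the scatter. For the measured compounds named here, its furthest is compound 1, whose number lies beyond the scatter above compound 2; compound 1 also carries a carbonyl on the shared core that compounds 2 and 3 lack, and no single step to it is available, so only its value stands beside theirs.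

The step under consideration leads to compound 4, `c1ccc(COc2ccc(C3CNCCS3)cc2)cc1`, through (phenyl in place of methyl on a saturated chain carbon bound to an oxygen on an aromatic ring). Going by the values given here, the one measured step at the same place is a 1.5-fold lower number from compound 2 to compound 3 (0.16 log units; within the scatter), a lengthening of the alkoxy chain that stayed within the scatter. The change to compound 4 is larger in kind, bringing in a ring rather than one further chain carbon, so the measured step gives only a weak anchor. Nothing in the series points to a rise; a modest fall in the number is the expectation, and the step from compound 2 is estimated as a 2.4-fold lower number from compound 2 to compound 4 (0.38 log units; beyond the scatter). Compound 4 is therefore expected to give about 4000 nM in this assay, with a range from 1000 nM to 15000 nM.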

Compound 4, inhibition constant: > 100000 nM
Compound 4: a limit, no number (the forecaster's own chance of this, stated with the estimate: 5%); middle value at least 25-fold (1.39 log units) away from the limit.
By their numbers in this assay, from the lowest: compounds 3 and 2 (each within the scatter of the next); then compound 1. At a limit, above all of these: compound 4.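

In this assay compound 4 gives > 100000 nM, which is a limit and not a number. At the saturated chain carbon bound to an oxygen on an aromatic ring, the series now shows that the outcome depends strongly on the group: the earlier extension, a 1.5-fold lower number from compound 2 to compound 3 (0.16 log units; within the scatter), gave no change beyond the scatter, whereas phenyl in place of methyl gives an at least 10-fold higher number from compound 2 to compound 4 (1.01 log units; beyond the scatter), and phenyl in place of ethyl gives an at least 15-fold higher number from compound 3 to compound 4 (1.17 log units; beyond the scatter). The full size of these two large steps stays unknown because compound 4 stands at a limit: the limit of > 100000 nM in this assay, at which 1 of the 4 values shown sits.

The compounds shown leave open whether the number already climbs with a longer saturated chain such as butyl, or whether a cyclohexyl ring in place of the phenyl gives the same loss as the aromatic ring. Also open, going by these compounds, is whether a fluorine or a methoxy group on the added phenyl, or a two-carbon link between that phenyl and the oxygen, would bring the number back within measurable range.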